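This account rests on a few compounds, and the source may have more. Where it says the series, first, only, none or still open, it means among the compounds named here.

Measured so far in an assay on isolated protein for inhibition of ubiquitin carboxyl-terminal hydrolase 7 (Homo sapiens), with stated times of 30 min and 2 h; on this read-out higher numbers stand for weaker inhibition and lower numbers for stronger inhibition:
compound 1 `Cn1cc(-c2ccc(CN3CCC(O)(Cn4cnc5c(-c6ccc(CN)cc6)n(C)nc5c4=O)CC3)c(Cl)c2)cn1` gives 291 nM
compound 2 `Cn1nc2c(=O)n(CC3(O)CCN(Cc4ccc(-c5ccco5)cc4Cl)CC3)cnc2c1-c1ccc(C(F)(F)F)cc1` gives 530 nM
compound 3 `Cn1nc2c(=O)n(CC3(O)CCN(Cc4ccc(-c5ccco5)cc4Cl)CC3)cnc2c1-c1ccc(OC(F)F)cc1` gives 179 nM

The three numbers lie close together. Compound 1 differs from compound 3 and from compound 2 by amounts that fall within the usual scatter of repeated measurements, so no ranking among these three can be drawn from the numbers themselves.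

Compound 4 `Cc1ccc(-c2ccc(CN3CCC(O)(Cn4cnc5c(-c6ccc(CN)cc6)n(C)nc5c4=O)CC3)c(Cl)c2)s1` is the next compound. Its difference from compound 1 is 5-methylthiophen-2-yl in place of 1-methyl-1H-pyrazol-4-yl on an aromatic carbon.

Among the measured compounds shown here, only one measured step exists, and it concerns a different part of the shared core: a 3.0-fold lower number from compound 2 to compound 3 (0.47 log units; beyond the scatter), a modest change that swaps one substituent on an aromatic carbon. For the measured compounds named here, no measured pair exchanges one five-membered aromatic ring for another, so nothing in these numbers speaks directly to the change from compound 1 to compound 4. The step from compound 2 to compound 3 shows that a single group swap can move the number by a modest amount, but its direction cannot be carried over to an unrelated position.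

The estimate for compound 4 is therefore anchored on compound 1 and expected to show a 1.0-fold higher number from compound 1 to compound 4 (0.01 log units; within the scatter), that is, nothing beyond the scatter. The expected value for compound 4 is 300 nM, in a range from 120 nM to 750 nM.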

Compound 4, half-maximal inhibitory concentration: 101 nM
For compound 4 the middle estimate is 3.0-fold (0.47 log units) above the measured one; the measured number lies below the stated range.
By their numbers in this assay, from the lowest: compounds 4, 3, 1 and 2 (each within the scatter of the next, the first and the last beyond it).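

In this assay, placing 5-methylthiophen-2-yl instead of 1-methyl-1H-pyrazol-4-yl on the carbon-only six-membered aromatic ring, meta to the chloro group, gives a 2.9-fold lower number from compound 1 to compound 4 (0.46 log units; beyond the scatter) and is a modest step. Among the compounds shown here, this shows that the position is not indifferent to which five-membered aromatic ring it carries, something the earlier compounds could not show, as their only measured step lay elsewhere in the molecule. The heavy-atom count is the same in the group that leaves and the group that enters, so exchanging one ring for another can shift the number without any added atoms, and no measurement shown gives a reason for this step.

Compounds 1 and 4 differ in both the ring and its methyl group, so they do not separate the contribution of the sulfur-containing ring from that of the methyl on it, a question that a plain thiophen-2-yl group would address. Going by these compounds, it also remains open how this position would respond to a six-membered ring such as pyridine or to a non-aromatic ring such as morpholine.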